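The source may hold more compounds than are shown below. What is called first, only, known or untested is meant among the compounds shown, and "the series" means these compounds.

For the measured compounds named here, in a functional assay on MCF7 cells (Homo sapiens) for antiproliferative activity, read by MTT assay, with a stated time of 24 h (on this read-out higher numbers stand for weaker inhibition and lower numbers for stronger inhibition), compound 1 `O=S(=O)(c1ccccc1)n1c(-c2cn(-c3ccccc3)nc2-c2ccc(C(F)(F)F)cc2)nc2ccccc21` gives 630 nM as the lower of the two numbers measured so far. Compound 2 `O=S(=O)(c1ccc(Cl)cc1)n1c(-c2cn(-c3ccccc3)nc2-c2ccc(C(F)(F)F)cc2)nc2ccccc21` gives 4320 nM as the higher number, which makes it the weaker inhibitor of the pair. Going by the values given here, the one measured step is a 6.9-fold higher number from compound 1 to compound 2 (0.84 log units; beyond the scatter) for chloro in place of hydrogen on an aromatic carbon. Compound 3 `O=S(=O)(c1ccc(Br)cc1)n1c(-c2cn(-c3ccccc3)nc2-c2ccc(C(F)(F)F)cc2)nc2ccccc21` is still unmeasured and carries bromo in place of chloro on an aromatic carbon, para to a large group (bromo in place of chloro on an aromatic carbon). Among the compounds with values here, no measured step replaces chloro with bromo, so the earlier step bears on this change only indirectly. Compound 2 remains the closest guide. In this assay the change is expected to stay within the scatter, with no firm direction, and the estimated step is a 1.1-fold lower number from compound 2 to compound 3 (0.03 log units; within the scatter) in size. Compound 3 is estimated at 4000 nM with an expected range from 1600 nM to 10000 nM in a repeat measurement.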

Compound 3, half-maximal inhibitory concentration: 2470 nM
The estimate for compound 3 lay 1.6-fold (0.21 log units) above the measured number; the range from low to high includes it.
By their numbers in this assay, from the lowest: compound 1; then compounds 3 and 2 (each within the scatter of the next).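

In this assay, bromo and chloro on this aromatic carbon cannot be told apart, as a 1.7-fold lower number from compound 2 to compound 3 (0.24 log units; within the scatter) stays within the usual scatter of repeated measurements. Bromo also gives a 3.9-fold higher number from compound 1 to compound 3 (0.59 log units; beyond the scatter) and so stands beyond the scatter from hydrogen, which means that among these three compounds both halogens give weaker inhibition than hydrogen, with no compound going against this. No available evidence explains this shared result.

The compounds shown carry only hydrogen, chloro or bromo at this place, so the pattern has been seen only with these two halogens. On these data alone, it remains open whether a methoxy group, an amine or a carboxylic acid on this carbon would give numbers closer to those of the halogens or to that of hydrogen.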